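The source may hold more compounds than are shown below. What is called first, only, known or untested is meant among the compounds shown, and "the series" means these compounds.

Measured so far in a functional assay on COLO 205 cells (Homo sapiens) for inhibition, read by sulforhodamine B assay, with a stated time of 48 h, tested at 50 uM; a lower number here means less inhibition of growth, a higher number more inhibition of growth at the concentration tested:

Compound 1 `COc1cc(/C=C/C(=O)/C=C/c2cccc3ccccc23)ccc1OCc1cn(CCCOc2cc(=O)oc3ccccc23)nn1`: 64%
Compound 2 `COc1ccc(/C=C/C(=O)/C=C/c2ccc(OCc3cn(CCCCOc4cc(=O)oc5ccccc45)nn3)c(OC)c2)cc1OC`: 53%

Compound 2 gives 53% and is the lower of the two, while compound 1 gives 64% and lies above it by more than the usual scatter of this kind of measurement. These two compounds differ in more than one place, so their gap cannot be tied to any single group.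

Compound 3 `COc1cc(/C=C/C(=O)/C=C/c2ccco2)ccc1OCc1cn(CCCCOc2cc(=O)oc3ccccc23)nn1` has not been measured yet. Its difference from compound 2 is furan-2-yl in place of 3,4-dimethoxyphenyl on a double-bonded chain carbon bound to a double-bonded chain carbon and it amounts to furan-2-yl in place of 3,4-dimethoxyphenyl on a double-bonded chain carbon bound to a double-bonded chain carbon.

Among the compounds with values here, no measured pair shows this change or any other single change, so the guide is weak. With compound 2 at 53% as the starting point, no step beyond the scatter is expected in this assay in either direction. The estimate corresponds to a small upward step of a number 2 percentage points higher from compound 2 to compound 3 (within the scatter) and this lies within the scatter. In this assay compound 3 is estimated at 55% with 38% to 72% as the expected range.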

Compound 3, percent growth inhibition at one concentration: 43%
Compound 3: middle estimate off by 12 percentage points, on the high side, and the stated range covers the measured number.
By their numbers in this assay, from the lowest: compounds 3 and 2 (each within the scatter of the next); then compound 1.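

In this assay, putting furan-2-yl in place of 3,4-dimethoxyphenyl on a double-bonded chain carbon bound to a double-bonded chain carbon gives a number 10 percentage points lower from compound 2 to compound 3 (within the scatter). Within the data shown here, this is the first single change that can be read, and it shows that this place can take a much smaller group, with fewer heavy atoms and a five-membered aromatic ring instead of a six-membered one, without a difference that clears the usual scatter of this measurement. Nothing available explains this result or shows which feature of either group matters for growth inhibition.

One swap at a single test concentration cannot show how far this place would accept other groups, such as a phenyl ring carrying an amine or a carboxylic acid. From the compounds shown here alone, the effect of the chain that links the triazole to the rest of the molecule also remains open, since a longer chain, such as a hexyl linker, would be needed alongside the butyl-length chain that compound 2 and compound 3 share.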